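The compounds below may be only part of what the source reports. "The series", "measured", "known", "first", "only" and "open" are said of these compounds alone.

Of the compounds shown here, two have so far been tested in a functional assay on MDA-MB-231 cells (Homo sapiens) for cytotoxicity, read by sulforhodamine B assay, with a stated time of 72 h; a higher number here means a weaker inhibitor of growth, a lower number a stronger inhibitor of growth. Compound 1 `O=C(Nc1ccc(C(F)(F)F)cc1)C1CCc2ccccc2N1` gives 24200 nM in this assay. Compound 2 `CCCC(=O)N1c2ccccc2CCC1C(=O)Nc1ccccc1C(F)(F)F` reaches only the limit of this assay, > 70000 nM, and so has no number of its own. Among the measured compounds shown here, of the two values shown, one sits at that limit (the limit of > 70000 nM in this assay, at which 1 of the 2 values shown sits), which places compound 2 at the weak end of what has been measured, while compound 1 is the only compound that carries a number. Compound 3 `CCCCCCCCC(=O)N1c2ccccc2CCC1C(=O)Nc1ccccc1C(F)(F)F` has yet to be tested in this assay. It differs from compound 2 in one place: pentyl in place of hydrogen on a saturated chain carbon, three bonds along the chain from a carbonyl carbon. For the measured compounds named here, no measured pair shows this kind of change, so no step of known size can be read from the data. The expected step is an at least 1.1-fold lower number from compound 2 to compound 3 (0.06 log units; that floor lies within the scatter), with neither direction favoured beyond the scatter. Compound 3 is therefore estimated at 60000 nM, within a range from 15000 nM to 200000 nM, and with a fair chance that it too returns only a limit.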

Compound 3, concentration for 50% growth inhibition: 3350 nM
Compound 3: middle estimate off by 18-fold (1.25 log units), on the high side; measured number below the stated range.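

The change at this position is far from neutral: pentyl in place of hydrogen on a saturated chain carbon, three bonds along the chain from a carbonyl carbon, gives an at least 20-fold lower number from compound 2 to compound 3 (1.32 log units; beyond the scatter) in this assay. The added group is a plain chain with no ring, no hydrogen-bond donors or acceptors and no net charge, so extending the chain alone is enough to produce a step beyond the scatter. The size of that step is only a floor, and the real gap may be wider, because compound 2 has a limit and not a number: the limit of > 70000 nM in this assay, at which 1 of the 3 values shown sits.

Among the compounds shown here, with only this one pair of chains, propyl and octyl as the same difference reads when cut further out, it remains open whether the gain builds steadily along the chain or appears only past a certain length. On these data alone, it is also open whether a longer chain would lower the number further, or whether a chain ending in a carboxylic acid or an amine would keep the gain.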